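The source may report more compounds than this note shows. Statements on the series, on what has been measured and on what is new or still open speak of the compounds shown alone.

Series measured in an assay on Sf9 cells for inhibition of histone-lysine N-methyltransferase EZH2 (Homo sapiens), read by scintillation counting, with a stated time of 60 min, in the presence of a further agent that is not named here; a higher number here means a weaker inhibitor, a lower number a stronger inhibitor:

compound 1 `Cc1cc(C)c(CNC(=O)c2cccc(OC(C)C)c2C)c(=O)[nH]1` — 1400 nM
compound 2 `COc1cccc(C(=O)NCc2c(C)cc(C)[nH]c2=O)c1C` — 5700 nM
compound 3 `COc1ccc2c(c1Cl)C(=O)N(Cc1c(C)cc(C)[nH]c1=O)CCC2` — 150 nM

Compound 2 has the highest of the three numbers in this assay. Among the compounds with values here, its nearest neighbour is compound 1, the step of a 4.1-fold higher number from compound 1 to compound 2 (0.61 log units; beyond the scatter) being the one single-place change measured so far. Within the data shown here, compound 3 stands furthest from compound 2; no single-place step between them is tabulated, so only the two values speak, and compound 3 is the lower of the pair.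

Compound 4 `COc1cccc(C(=O)NCc2c(C)cc(C)[nH]c2=O)c1` differs from compound 2 in one place: hydrogen in place of methyl on an aromatic carbon. Among the measured compounds shown here, none of the measured steps bears directly on this change; the only measured step concerns the group on the oxygen, not a substituent on the ring carbon. The size and direction of the step in this assay are therefore not fixed by the data, and the expectation is a modest move toward a higher number or none beyond the scatter: a 1.6-fold higher number from compound 2 to compound 4 (0.20 log units; within the scatter). For compound 4 the estimated value in this assay is 9000 nM, with a range of 3000 nM to 27000 nM.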

Compound 4, half-maximal inhibitory concentration: > 150000 nM
Compound 4 was reported as a limit; the forecaster's own chance of this, stated with the estimate: 20%; at least 16-fold (1.22 log units) between middle value and limit.
By their numbers in this assay, from the lowest: compound 3; then compound 1; then compound 2. At a limit, above all of these: compound 4.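

In this assay, removing the methyl from this aromatic carbon, ortho to a large group and ortho to a methoxy group, gives an at least 26-fold higher number from compound 2 to compound 4 (1.42 log units; beyond the scatter). Within the data shown here, that step is larger than the only earlier single-place step, the change on the oxygen, a 4.1-fold higher number from compound 1 to compound 2 (0.61 log units; beyond the scatter). Compound 4 stands only as a limit, > 150000 nM, so a single methyl here separates a measured value from the one result in the series that is a limit: the limit of > 150000 nM in this assay, at which 1 of the 4 values shown sits.

Going by these compounds, whether an ethyl, a chlorine or a trifluoromethyl group on this aromatic carbon would give a measurable value remains open. Also open, on these data alone, is whether an isopropyl on the oxygen, as in compound 1, would change the size of the step when the methyl is replaced by hydrogen.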